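A few compounds are considered here, and "the series" means these few. Any claim that something is new, unique, unknown or untested is made for them only; others in the source may bear on it.

Working notes on the series. Three compounds have been run so far in an assay on HEK293 cells for positive allosteric modulation of metabotropic glutamate receptor 3 (Rattus norvegicus), read by thallium flux, with a stated time of 2.5 min; a lower number here means that less compound is needed, a higher number that more compound is needed for the effect. Compound 1 `Cc1c(OCCCCOc2ccccc2C(=O)O)ccc(C(=O)CC2CCCC2)c1O` and compound 3 `Cc1c(OCCCCOc2ccc(F)c(C(=O)O)c2)ccc(C(=O)CC2CCCC2)c1C` give no single number in this assay; compound 1 stands at "not determined" (no result reported) and compound 3 at "not determined" (no result reported), so neither anchors the series. Among the compounds with values here, compound 2 `Cc1c(OCCCCOc2ccc(F)c(C(=O)O)c2)ccc(C(=O)CC(C)(C)C)c1O` is the only one with a number: in this assay compound 2 gives 258 nM. Within the data shown here, no step between two measured compounds can be drawn from these entries.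

The step considered here runs from compound 3 to compound 4 `Cc1c(OCCCCOc2ccc(F)c(C(=O)O)c2)ccc(C(=O)CC2CCCC2)c1O`. The difference between the two is hydroxy in place of methyl on an aromatic carbon. Among the measured compounds shown here, no matched step of this kind is available, so the size and direction of the change in this assay cannot be read off; it is expected to move compound 4 by no more than the usual scatter, with no direction claimed.

Compound 4 is estimated to land at 300 nM, with a range from 100 nM to 900 nM, because compound 2 gives 258 nM in this assay and carries the same hydroxy group that enters in compound 4.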

Compound 4, half-maximal effective concentration: 2490 nM
Compound 4: the middle estimate sits 8.3-fold (0.92 log units) below what was measured; the whole stated range lies below it.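

The change from methyl to hydroxy on this aromatic carbon still has no size: compound 3 gives no number in this assay, so the step into compound 4 cannot be read. Within the data shown here, what compound 4 adds is the first readable step, with the hydroxy group kept and cyclopentyl in place of tert-butyl on the saturated chain carbon bound to the carbonyl carbon: there is a 9.7-fold higher number from compound 2 to compound 4 (0.98 log units; beyond the scatter). The shared hydroxy group therefore does not by itself set the number in this pair, and the change on the chain carbon alone moves it beyond the scatter, though no supporting data bear on the reason for this.

From the compounds shown here alone, whether hydroxy or methyl gives the lower number on this aromatic carbon stays open, as does what a methoxy group or an amine would give there. Also open, going by these compounds, is how other groups on the chain carbon, such as isopropyl or cyclohexyl, compare with cyclopentyl and tert-butyl, and whether the same step holds when methyl replaces the hydroxy group.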